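A Furan Ring Enters Where an Alkene Chain Leaves

The compounds below may be only part of what the source reports. "The series", "measured", "known", "first", "only" and "open" are said of these compounds alone.

Compound 1, `Brc1ccc(Br)c(N(CC2CC2)C2=NCCN2)c1`: in a physicochemical assay for acid dissociation, compound 1 gives 11.
Compound 2, `Brc1cccc(N(CC2CC2)C2=NCCN2)c1Br`: in this assay compound 2 gives 11.1.
Compound 3, `C/C=C/CN(C1=NCCN1)c1c(Br)cccc1Br`: in this assay compound 3 gives 11.

Compound 3 stands level with compound 1 at the digits shown, and the reading of compound 2 differs from that of compound 3 by an amount that lies within the usual scatter of this kind of measurement. Among the compounds with values here, the three measured compounds therefore give no step that a new compound could be set against; all three share one core, an imidazoline amidine on a dibromophenyl nitrogen, and differ only in what hangs from that nitrogen.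

Compound 4, `Brc1cccc(Br)c1N(Cc1ccco1)C1=NCCN1`, is the next compound to be measured. It differs from compound 3 in one place: furan-2-yl in place of prop-1-en-1-yl on a saturated chain carbon bound to a nitrogen on an aromatic ring. The change sits on the chain carbon bound to the nitrogen, away from the amidine that gives up the proton, and the measured compounds show that variation at that nitrogen has so far left the reading unmoved.

For compound 4 a step in this assay of a number 0.20 log units lower from compound 3 to compound 4 (within the scatter) is expected, no larger than the scatter. Compound 4 is estimated at 10.8, in a range from 10.4 to 11.2.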

Compound 4, acid dissociation constant: 10.5
For compound 4 the middle estimate is 0.30 log units above the measured one; the measured number falls inside the stated range.
By their numbers in this assay, from the lowest: compound 4; then compounds 1, 3 and 2 (each within the scatter of the next).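

In this assay the exchange of prop-1-en-1-yl for furan-2-yl on a saturated chain carbon bound to a nitrogen on an aromatic ring gives a number 0.50 log units lower from compound 3 to compound 4 (beyond the scatter), so in this pair the proton is given up more readily. Within the data shown here, this is the first step between two compounds that differ in one place, and it shows that a change at this position can move the reading beyond the scatter, which compounds 1, 2 and 3 could not show, as they offered no such step. No available evidence bears on why the reading moves with this change.

A single step cannot tell whether the shift goes with the ring oxygen of furan-2-yl or with the presence of a five-membered aromatic ring at all, and a thiophene or a plain phenyl ring on the same chain carbon would be needed to separate the two. On these data alone, it also remains open whether the same exchange gives a similar step on the core of compound 1 or of compound 2, where the bromines are arranged differently.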